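Aryl Swap on a Shared Core: Expectation for Compound 3

The source may report more compounds than this note shows. Statements on the series, on what has been measured and on what is new or still open speak of the compounds shown alone.

Compound 1 `COc1cc(/C=C/C(=O)c2cccc(-n3cc(-c4cc(F)cc(F)c4)nn3)c2)ccc1O`: 22800 nM
Compound 2 `COc1ccc(/C=C/C(=O)c2cccc(-n3cc(-c4ccc(Br)cc4)nn3)c2)cc1O`: 6570 nM

In a functional assay on RAW264.7 cells (Mus musculus) for inhibition, with a stated time of 4 days (a lower number here means a stronger inhibitor, a higher number a weaker inhibitor), compound 1 gives 22800 nM, and compound 2 gives 6570 nM, the lower of the two numbers, with compound 1 beyond the scatter above it. Compound 3 `COc1ccc(/C=C/C(=O)c2cccc(-n3cc(-c4cc(F)cc(F)c4)nn3)c2)cc1O` differs from compound 2 by 3,5-difluorophenyl in place of 4-bromophenyl on an aromatic carbon. Going by the values given here, no measured pair isolates this change, yet compound 1, which also carries the 3,5-difluorophenyl, gave the higher 22800 nM. Compound 3 is therefore expected to be a somewhat weaker inhibitor, with a 1.8-fold higher number from compound 2 to compound 3 (0.26 log units; within the scatter) as a moderate step. The estimate for compound 3 is 12000 nM, ranging from 4500 nM to 32000 nM.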

Compound 3, half-maximal inhibitory concentration: 7140 nM
The estimate for compound 3 lay 1.7-fold (0.23 log units) above the measured number, within the range that was stated.
By their numbers in this assay, from the lowest: compounds 2 and 3 (each within the scatter of the next); then compound 1.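

In this assay, 3,5-difluorophenyl in place of 4-bromophenyl on the aromatic carbon gives a 1.1-fold higher number from compound 2 to compound 3 (0.04 log units; within the scatter), so the two aryl groups are not told apart at this position on the shared core. The larger step instead comes with 3-hydroxy-4-methoxyphenyl in place of 4-hydroxy-3-methoxyphenyl on the double-bonded chain carbon, a 3.2-fold lower number from compound 1 to compound 3 (0.50 log units; beyond the scatter). Nothing available explains either result. Open, as far as these compounds go, is whether an amine or a carboxylic acid on this aryl ring would separate from these two groups. Also open, from the compounds shown here alone, is whether the hydroxy and methoxy preference holds with 4-bromophenyl.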